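The source may report more compounds than this note shows. Statements on the series, on what has been measured and on what is new or still open speak of the compounds shown alone.

Measured compounds in this series:

compound 1 `CCOC(=O)CCCCCOc1ccc2c(=O)c(-c3ccc(O)cc3)coc2c1`: 280 nM
compound 2 `CCCCC(Oc1ccc2c(=O)c(-c3ccc(O)cc3)coc2c1)C(=O)OCC`: 4500 nM
compound 3 `C=CCOc1ccc2c(=O)c(-c3ccc(O)cc3)coc2c1`: 180 nM

In an assay (Cricetulus griseus) for inhibition of aldehyde dehydrogenase, mitochondrial (Homo sapiens) (on this read-out higher numbers stand for weaker inhibition and lower numbers for stronger inhibition), compound 1 stands second highest of the three numbers. For the measured compounds named here, its nearest neighbour is compound 3, reached by a 1.6-fold lower number from compound 1 to compound 3 (0.19 log units; within the scatter); compound 2 gives the number furthest from it, beyond the scatter, and no single-point step connects compound 2 to compound 1.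

The next compound, compound 4 `O=C(O)CCCCCCCCCOc1ccc2c(=O)c(-c3ccc(O)cc3)coc2c1`, differs from compound 1 in one place: 4-carboxybutyl in place of ethoxycarbonyl on a saturated chain carbon, five bonds along the chain from an oxygen on an aromatic ring. The chain keeps its ether attachment to the core and is lengthened at its far end, with a free acid taking the place of the ester.

Going by the values given here, only one measured step bears on this. The step of a 1.6-fold lower number from compound 1 to compound 3 (0.19 log units; within the scatter) shows that removing the whole ester-bearing chain and leaving a short vinyl in its place moves the number no further than the scatter, so the tail of this chain is not what sets the value here. Nothing measured in this assay speaks to a free acid at the chain end, and compound 2 cannot be used since its change sits elsewhere on the chain. On this basis compound 4 is expected to stay close to compound 1, with a 1.1-fold higher number from compound 1 to compound 4 (0.03 log units; within the scatter) not beyond the scatter; the estimate for compound 4 is 300 nM, within 120 nM to 800 nM.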

Compound 4, half-maximal inhibitory concentration: 50 nM
Compound 4: the middle estimate sits 6.0-fold (0.78 log units) above what was measured; the whole stated range lies above it.
By their numbers in this assay, from the lowest: compound 4; then compounds 3 and 1 (each within the scatter of the next); then compound 2.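

In this assay the step of a 5.6-fold lower number from compound 1 to compound 4 (0.75 log units; beyond the scatter) comes with 4-carboxybutyl in place of ethoxycarbonyl on a saturated chain carbon, five bonds along the chain from an oxygen on an aromatic ring. The earlier step of a 1.6-fold lower number from compound 1 to compound 3 (0.19 log units; within the scatter) gave no sign that the chain end mattered, whereas this result shows that what stands at the far end of the ether chain can shift the number towards stronger inhibition. Nothing available accounts for this shift.

Compound 4 differs from compound 1 in both the end group and the chain length, so the compounds shown leave open whether the free carboxylic acid, the longer chain or the two together carry the step; an ethyl ester on the longer chain and a carboxylic acid on the shorter chain of compound 1 would separate these. Also open, as far as these compounds go, is whether a primary amide or an alcohol at the chain end, or a still longer chain ending in a carboxylic acid, would hold the number of compound 4.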